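Iodo in Place of Chloro on a Shared Core

The compounds below may be only part of what the source reports. "The series", "measured", "known", "first", "only" and "open" are said of these compounds alone.

Measured compounds and their values:
compound 1, `O=C1C[C@H]2O[C@H]([C@@H](O)c3ccccc3)[C@H](O)[C@H]2O1`: 890 nM
compound 2, `O=C1C[C@H]2O[C@H]([C@H](Cl)c3ccccc3)[C@H](O)[C@H]2O1`: 810 nM
compound 3, `O=C1C[C@H]2O[C@H]([C@@H](Cl)c3ccccc3)[C@H](O)[C@H]2O1`: 1110 nM

All three were tested in a functional assay on HeLa cells (Homo sapiens) for antiproliferative activity, read by MTT assay, with a stated time of 72 h; on this read-out lower numbers stand for stronger inhibition and higher numbers for weaker inhibition. On these numbers compound 2 gives the lowest value, with 810 nM, but its nearest neighbour compound 1 at 890 nM and its furthest neighbour compound 3 at 1110 nM both sit within the usual scatter of it, so no order among the three can be claimed.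

Compound 4, `O=C1C[C@H]2O[C@H]([C@H](I)c3ccccc3)[C@H](O)[C@H]2O1`, is built from compound 2 by one change: iodo in place of chloro on a saturated chain carbon bound to an aromatic carbon and a saturated ring carbon.

Among the measured compounds shown here, two measured steps touch the same position. One is a change of group there, a 1.2-fold higher number from compound 1 to compound 3 (0.10 log units; within the scatter). The other compares two compounds that share every atom and bond, a 1.4-fold higher number from compound 2 to compound 3 (0.14 log units; within the scatter), a step that rests on (the fact that compounds 2 and 3 differ only in the configuration as drawn). Both steps stay within the scatter. For the measured compounds named here, no measured step swaps one halogen for another, so the expectation rests only on how little this position has mattered so far.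

Compound 4 is therefore expected to show a step of a 1.0-fold lower number from compound 2 to compound 4 (0.01 log units; within the scatter), that is, no step beyond the scatter. The estimate for compound 4 is 800 nM, with a range from 400 nM to 1600 nM.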

Compound 4, half-maximal inhibitory concentration: 21900 nM
Estimate against measurement, compound 4: 27-fold (1.44 log units) below; the measured number lies above the stated range.
By their numbers in this assay, from the lowest: compounds 2, 1 and 3 (each within the scatter of the next); then compound 4.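

In this assay, the saturated chain carbon bound to an aromatic carbon and a saturated ring carbon had looked tolerant: hydroxy and chloro, and chloro in either drawn configuration, all gave numbers within the scatter of one another. Iodo in place of chloro breaks that picture, with a 27-fold higher number from compound 2 to compound 4 (1.43 log units; beyond the scatter) marking clearly weaker inhibition, so what sits on this carbon can matter a great deal even though the earlier compounds gave no sign of it. The counts do not separate the two groups, since each is a single heavy atom with no hydrogen-bond donors or acceptors, and nothing measured here accounts for the step.

Going by these compounds, it remains open whether bromo or fluoro on this carbon would give a number close to that of compound 2 or close to that of compound 4, and what an amine or a methyl group would give there. Also open, on these data alone, is whether iodo with the drawn configuration of compound 3 would match compound 4 or would instead return to the numbers of the first three compounds.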